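This account rests on a few compounds, and the source may have more. Where it says the series, first, only, none or still open, it means among the compounds named here.

Compound 3 `O=c1oc2ccc(F)cc2n1Cc1cccc(F)c1` gives 28500 nM in an assay on HeLa cells for inhibition of Indoleamine 2,3-dioxygenase 1 (Homo sapiens), with a stated time of 24 h (a higher number here means a weaker inhibitor, a lower number a stronger inhibitor), the highest of the three numbers recorded so far. Compound 1 `O=c1oc2ccc(Cl)cc2n1Cc1cccc(F)c1` gives 9750 nM in this assay, and compound 2 `O=c1oc2ccc(Cl)cc2n1Cc1ccc(Cl)cc1` gives 6080 nM in this assay. Among the compounds with values here, the one single-point change measured on the shared core is the step of a 2.9-fold higher number from compound 1 to compound 3 (0.47 log units; beyond the scatter). Compound 4 `O=c1oc2ccc([N+](=O)[O-])cc2n1Cc1cccc(F)c1` differs from compound 3 by nitro in place of fluoro on an aromatic carbon. Within the data shown here, the step from compound 1 to compound 3 is the only measured step that bears on this change, since it sits at the same place on the core; it shows that a chloro at that place gave a lower number than a fluoro, but it says nothing about a nitro, and no measured pair shows a nitro anywhere. Whether compound 4 will come out nearer to compound 1 or nearer to compound 3 cannot be read from the three compounds in hand, so the expectation is loose. Compound 4 is expected to give roughly 12000 nM in this assay, within a range of 3000 nM to 45000 nM. This amounts to an expected step of a 2.4-fold lower number from compound 3 to compound 4 (0.38 log units; beyond the scatter), a modest move toward a lower number that may well fall inside the scatter.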

Compound 4, half-maximal inhibitory concentration: 99800 nM
Compound 4: the middle estimate sits 8.3-fold (0.92 log units) below what was measured; measured number above the stated range.
By their numbers in this assay, from the lowest: compounds 2 and 1 (each within the scatter of the next); then compound 3; then compound 4.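

Nitro at this place does not move the number toward that of the chloro compound, as the single earlier step might have suggested; it goes the other way, with a 3.5-fold higher number from compound 3 to compound 4 (0.54 log units; beyond the scatter) in this assay. Within the data shown here, measured against the chloro compound, the same replacement gives a 10-fold higher number from compound 1 to compound 4 (1.01 log units; beyond the scatter), the only large step so far. With a 2.9-fold higher number from compound 1 to compound 3 (0.47 log units; beyond the scatter) added, the three groups at this one aromatic carbon fall in a clear order, chloro lowest, then fluoro, then nitro, each separated from the next by more than the scatter, so this place on the shared core is sensitive to what it carries, and a nitro there gives the weakest inhibitor of the three compounds compared at this place. Going by these compounds, how an amine, a methoxy group or a nitrile at this place would fall within that order remains open, as does whether the order would hold with the other substituent carried by compound 2. The compounds shown come with no evidence that would explain the order of these three groups.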